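From Amide to Urea on a Shared Core

The compounds below may be only part of what the source reports. "The series", "measured", "known", "first", "only" and "open" are said of these compounds alone.

Measured compounds:
compound 1 `COc1cc(-c2nn(-c3cccc(NC(=O)c4cccc(C(F)(F)F)c4)c3)cc2-c2ccncc2)ccc1Cl` — 5170 nM
compound 2 `O=C(Nc1cccc(-n2cc(-c3ccncc3)c(-c3ccc(Cl)c(O)c3)n2)c1)Nc1ccc(Cl)c(C(F)(F)F)c1` — 6750 nM

Both compounds were tested in a functional assay on COLO 205 cells (Homo sapiens) for inhibition, read by sulforhodamine B assay, with a stated time of 48 h; a lower number here means a stronger inhibitor of growth, a higher number a weaker inhibitor of growth. In this assay compound 1 gives 5170 nM, the lowest of the two numbers; compound 2 gives 6750 nM, and the two values lie within the usual scatter of each other, so no order between them can be read. Compound 2 differs from compound 1 in more than one place, and only their two values are known.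

Compound 3 `COc1cc(-c2nn(-c3cccc(NC(=O)Nc4ccc(Cl)c(Cl)c4)c3)cc2-c2ccncc2)ccc1Cl` has not been measured. It differs from compound 1 in one place: (3,4-dichlorophenyl)amino in place of 3-(trifluoromethyl)phenyl on a carbonyl carbon. Cut one bond further out, the change reads as (3-(trifluoromethyl)phenyl)carbonyl to (3,4-dichlorophenyl)carbamoyl. For the measured compounds named here, no measured pair shows this change alone. Compound 2 also holds a carbamoyl group and gives a value near that of compound 1, but it differs in other places too, so it supports only a loose expectation. For compound 3 a step of no size beyond the scatter is expected, a 1.1-fold lower number from compound 1 to compound 3 (0.06 log units; within the scatter). Compound 3 is therefore estimated at 4500 nM, with a range from 1500 nM to 13000 nM.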

Compound 3, concentration for total growth inhibition: 1720 nM
Compound 3: the middle estimate sits 2.6-fold (0.42 log units) above what was measured; the range from low to high includes it.
By their numbers in this assay, from the lowest: compound 3; then compounds 1 and 2 (each within the scatter of the next).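

In this assay, for the compounds shown here, putting (3,4-dichlorophenyl)amino in place of 3-(trifluoromethyl)phenyl on a carbonyl carbon gives a 3.0-fold lower number from compound 1 to compound 3 (0.48 log units; beyond the scatter) and so provides the first comparison here in which only one place differs. It shows that the group on this carbonyl carbon can move the number beyond the scatter, though only modestly, something the pair of compound 1 and compound 2 could not show with more than one place differing. The change alters several features at once, bringing in a nitrogen with 1 hydrogen-bond donor and two chlorine atoms while removing the 3 fluorine atoms, and no measurement here explains why the number falls.

On these data alone, it remains open whether the step comes from the amino link or from the ring substituents, which could be separated by (3-(trifluoromethyl)phenyl)amino or 3,4-dichlorophenyl on the same carbonyl carbon. Also open, as far as these compounds go, is whether a piperidine or a simple butyl chain in this place would keep the lower number of compound 3 or lose it.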